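Chloro in place of hydrogen on a purine core

The compounds below may be only part of what the source reports. "The series", "measured", "known", "first", "only" and "open" are said of these compounds alone.

In a functional assay on KM12 cells (Homo sapiens) for cytotoxicity, read by sulforhodamine B assay, with a stated time of 48 h (on this read-out lower numbers stand for higher toxicity in this test and higher numbers for lower toxicity in this test), three compounds sharing a purine-like core with a chloromethyl-substituted benzyl group have been measured. Compound 1 `ClCc1cccc(Cn2cnc3c(Cl)nc(Cl)nc32)c1` gives 7940 nM, compound 2 `ClCc1ccccc1Cn1cnc2ncnc(Cl)c21` gives 38000 nM, and compound 3 `Nc1nc(Cl)c2ncn(Cc3cccc(CCl)c3)c2n1` gives 37200 nM. Compound 2 stands with the highest number of the three; its value and that of compound 3 lie within the scatter of each other, while compound 1 sits well apart with the lower number. Within the data shown here, the only single-point step among them, a 4.7-fold higher number from compound 1 to compound 3 (0.67 log units; beyond the scatter), shows a modest move toward higher numbers when amino replaces chloro.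

Compound 4 `ClCc1ccccc1Cn1cnc2nc(Cl)nc(Cl)c21` has not yet been measured. It differs from compound 2 by chloro in place of hydrogen on an aromatic carbon. Among the measured compounds shown here, no measured pair isolates exactly this change. Still, compound 1, which carries chloro at this position and gives 7940 nM, lies below compound 2 and compound 3, and the step from compound 1 to compound 3 points the same way. He therefore expects a lower number for compound 4 in this assay, estimated as a 3.2-fold lower number from compound 2 to compound 4 (0.50 log units; beyond the scatter). Compound 4 is expected to give 12000 nM, between 4000 nM and 40000 nM.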

Compound 4, concentration lethal to 50% of the cells: 56200 nM
Compound 4: the middle estimate sits 4.7-fold (0.67 log units) below what was measured; measured number outside the range, above it.
By their numbers in this assay, from the lowest: compound 1; then compounds 3, 2 and 4 (each within the scatter of the next).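

In this assay, the step from hydrogen to chloro on the aromatic carbon between two ring nitrogen atoms can now be read directly, as a 1.5-fold higher number from compound 2 to compound 4 (0.17 log units; within the scatter), and it lies within the scatter. With the rest of compound 2 held fixed, this chloro leaves no measurable mark on the number, so this pair gives no support for linking it to lower numbers, and the low number of compound 1 has to be read apart from it. No evidence at hand explains why this change leaves the number in place.

As far as these compounds go, whether methoxy or a carboxylic acid on this carbon would leave the number equally unmoved stays open. So does whether chloro here would do the same with the chloromethyl group elsewhere on the benzyl ring.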